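Pyridyl nitrogen position and cytotoxicity in a matched pair

The source may report more compounds than this note shows. Statements on the series, on what has been measured and on what is new or still open speak of the compounds shown alone.

Measured compounds:
compound 1 `C[C@@H](NC(=O)[C@H](CCCNC(=N)N)NC(=O)c1ccc(CN(Cc2ccncc2)Cc2ccc(F)cc2)cc1)c1cccc2ccccc12` gives 39000 nM
compound 2 `C[C@H](NC(=O)[C@H](CCCNC(=N)N)NC(=O)c1ccc(CN(Cc2ccc(F)cc2)Cc2cccnc2)cc1)c1cccc2ccccc12` gives 41000 nM

Both compounds were tested in an ADME assay on MT4 cells (Homo sapiens) for cytotoxicity; on this read-out higher numbers stand for lower toxicity in this test and lower numbers for higher toxicity in this test. In this assay compound 2 gives 41000 nM, and compound 1 gives 39000 nM; the two numbers lie within the usual scatter of each other, so nothing separates the pair beyond measurement noise. Compound 2 is the reference point for the next compound.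

Compound 3 `C[C@H](NC(=O)[C@H](CCCNC(=N)N)NC(=O)c1ccc(CN(Cc2ccncc2)Cc2ccc(F)cc2)cc1)c1cccc2ccccc12` has not yet been measured in this assay. It differs from compound 2 by pyridin-4-yl in place of pyridin-3-yl on a saturated chain carbon bound to an amine nitrogen, the same change read one bond further out as (pyridin-3-yl)methyl to (pyridin-4-yl)methyl. Among the measured compounds shown here, no measured pair shows this change in isolation, so there is no step to lean on. Compound 1, which also carries the pyridin-4-yl group, sits within the scatter of compound 2, which gives no hint of a shift in either direction.

The expected step from compound 2 to compound 3 is therefore a 1.0-fold lower number from compound 2 to compound 3 (0.01 log units; within the scatter), none beyond the scatter. Compound 3 is estimated at 40000 nM, within a range of 20000 nM to 80000 nM.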

Compound 3, half-maximal cytotoxic concentration: 44000 nM
Compound 3: the middle estimate sits 1.1-fold (0.04 log units) below what was measured; measured number inside the range.
By their numbers in this assay, from the lowest: compounds 1, 2 and 3 (each within the scatter of the next).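

Pyridin-4-yl in place of pyridin-3-yl on a saturated chain carbon bound to an amine nitrogen can now be read on its own, and in this assay it gives a 1.1-fold higher number from compound 2 to compound 3 (0.03 log units; within the scatter). The stereocentre at a saturated chain carbon can also be read on its own, and it gives a 1.1-fold higher number from compound 1 to compound 3 (0.05 log units; within the scatter), so neither single change separates its pair beyond measurement noise in these three compounds. The second reading carries one qualification about how the structures are drawn: the fact that one of compounds 1 and 3 is drawn with a defined configuration and the other without, at the place where they differ

As far as these compounds go, what stays open is whether a pyridin-2-yl group or a plain phenyl ring at this same place would separate from these compounds in this assay. Also open, from the compounds shown here alone, is whether the same two changes would stay within the scatter on a compound with a carboxylic acid or a longer chain elsewhere on the shared core.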